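Sulfonyl aryl variation and liver microsomal clearance

The source may report more compounds than this note shows. Statements on the series, on what has been measured and on what is new or still open speak of the compounds shown alone.

Measured so far:
compound 1 `O=S(=O)(c1cccc(F)c1)c1cnc2cc(F)ccc2c1-c1ccc(F)cc1`, 0.11 mL/min
compound 2 `COc1ccc(S(=O)(=O)c2cnc3cc(F)ccc3c2-c2ccc(F)cc2)cc1`, 1.71 mL/min

Both numbers come from an ADME assay on microsomes from liver (Homo sapiens) for metabolic stability, tested at 2.5 uM; a higher number here means faster removal of the compound, a lower number slower removal. Within the data shown here, compound 2 stands at the higher of the two values, and the single step in hand, a 16-fold higher number from compound 1 to compound 2 (1.19 log units; beyond the scatter), lies beyond the scatter.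

The next member is compound 3 `Cc1ccc(S(=O)(=O)c2cnc3cc(F)ccc3c2-c2ccc(F)cc2)cc1F`. It differs from compound 2 only at the sulfonyl sulfur: 3-fluoro-4-methylphenyl in place of 4-methoxyphenyl on a sulfonyl sulfur. Among the measured compounds shown here, the only step that bears on this change is the one from compound 1 to compound 2, which moved the read-out from the lower end to the higher end of the series. Compound 3 carries neither the 3-fluorophenyl of compound 1 nor the 4-methoxyphenyl of compound 2, so the outcome is not fixed by that step; a value between the two measured compounds is the working expectation, and a downward step from compound 2 is expected, a 3.4-fold lower number from compound 2 to compound 3 (0.53 log units; beyond the scatter). Compound 3 is therefore estimated at 0.5 mL/min in this assay, with a range of 0.15 mL/min to 1.5 mL/min.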

Compound 3, intrinsic clearance in a liver preparation (reported as CLH), per the amount of preparation that the assay uses: 2.33 mL/min
The estimate for compound 3 lay 4.7-fold (0.67 log units) below the measured number; measured number outside the range, above it.
By their numbers in this assay, from the lowest: compound 1; then compounds 2 and 3 (each within the scatter of the next).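

In this assay, 3-fluoro-4-methylphenyl in place of 4-methoxyphenyl on the sulfonyl sulfur gives (a 1.4-fold higher number from compound 2 to compound 3 (0.13 log units; within the scatter)), so the two groups cannot be told apart here, even though the group that leaves has a hydrogen-bond acceptor and the group that enters has none. The contrast lies in the pair that differs by one methyl: methyl in place of hydrogen on an aromatic carbon gives (a 21-fold higher number from compound 1 to compound 3 (1.33 log units; beyond the scatter)), so in this pair that single change on the sulfonyl aryl group separates a low number from a high one, and the 4-methoxyphenyl of compound 2 is not needed to reach the high end of the series. No measurement at hand accounts for either step.

From the compounds shown here alone, the large methyl step rests on one pair, so it remains open whether methyl in place of hydrogen has a similar size on other sulfonyl aryl groups or on a different core. Also open, going by these compounds, is whether a nitrile or an amine in place of that methyl would give a number like that of compound 1 or one like that of compound 3.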